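Chloro in Place of Methyl: What Compound 4 Should Give

The source may report more compounds than this note shows. Statements on the series, on what has been measured and on what is new or still open speak of the compounds shown alone.

Compound 3 `C=C1C[C@]23C[C@@]1(O)CC[C@H]2c1cc(Br)c(O)c(C)c1[C@@H]3Cn1cc(-c2ccc(C)cc2)nn1` gives only a limit in a functional assay on HL-60 cells (Homo sapiens) for cytotoxicity, read by MTT assay, with a stated time of 4 days (on this read-out higher numbers stand for weaker inhibition and lower numbers for stronger inhibition), namely > 20000 nM. On this read-out it therefore stands higher than either of its neighbours. Compound 4 `C=C1C[C@]23C[C@@]1(O)CC[C@H]2c1cc(Br)c(O)c(C)c1[C@@H]3Cn1cc(-c2ccc(Cl)cc2)nn1` differs from it by chloro in place of methyl on an aromatic carbon. For the measured compounds named here, two measured steps bear on that change. Compound 1 `C=C1C[C@]23C[C@@]1(O)CC[C@H]2c1cc(Br)c(O)c(C)c1[C@@H]3Cn1cc(-c2ccc(F)cc2)nn1` gives 6600 nM in this assay, and an at least 3.0-fold higher number from compound 1 to compound 3 (0.48 log units; beyond the scatter). Compound 2 `C=C1C[C@]23C[C@@]1(O)CC[C@H]2c1cc(Br)c(O)c(C)c1[C@@H]3Cn1cc(-c2ccc(C(F)(F)F)cc2)nn1` gives 7380 nM, and an at least 2.7-fold higher number from compound 2 to compound 3 (0.43 log units; beyond the scatter). Between the two, a 1.1-fold higher number from compound 1 to compound 2 (0.05 log units; within the scatter). Given that compounds 1 and 2 sit well inside the measurable range, compound 4 is expected to return toward them, a step in this assay of an at least 2.8-fold lower number from compound 3 to compound 4 (0.45 log units; beyond the scatter). Compound 4 is accordingly estimated at 7000 nM, within a range from 3000 nM to 20000 nM.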

Compound 4, half-maximal inhibitory concentration: 5590 nM
The estimate for compound 4 lay 1.3-fold (0.10 log units) above the measured number, within the range that was stated.
By their numbers in this assay, from the lowest: compounds 4, 1 and 2 (each within the scatter of the next). At a limit, above all of these: compound 3.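

In this assay, the change from 4-methylphenyl to 4-chlorophenyl gives an at least 3.5-fold lower number from compound 3 to compound 4 (0.55 log units; beyond the scatter) and so brings compound 4 out of the limit that holds compound 3, a limit and not a number: the limit of > 20000 nM in this assay, at which 1 of the 4 values shown sits. Chloro shows no separation from the other two halogen-bearing groups, with a 1.2-fold lower number from compound 1 to compound 4 (0.07 log units; within the scatter) and a 1.3-fold lower number from compound 2 to compound 4 (0.12 log units; within the scatter) in the same assay. Of the four groups at this position, methyl alone stands apart. From the compounds shown here alone, what an amine, a hydroxyl or a longer chain would give here stays open, as does the actual number for compound 3.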